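This account rests on a few compounds, and the source may have more. Where it says the series, first, only, none or still open, it means among the compounds named here.

Compound 1 `CC(C)n1ncc2c(C(=O)Nc3cccc(F)c3)cc(-c3cccs3)nc21` carries a 3-fluorophenyl group on the amide-type nitrogen of the shared core. In an ADME assay on LLC-MK2 cells (Macaca mulatta) for cytotoxicity, read by spectrophotometry and crystal violet staining, with a stated time of 4 days (on this read-out lower numbers stand for higher toxicity in this test and higher numbers for lower toxicity in this test), compound 1 gives > 200000 nM, which is a limit of the assay and not a number; compound 1 sits at the limit of > 200000 nM in this assay, at which 1 of the 3 values shown sits. Compound 2 `CNS(=O)(=O)c1cccc(NC(=O)c2cc(-c3cccs3)nc3c2cnn3C(C)C)c1` gives 25000 nM in this assay, and compound 3 `CC(C)n1ncc2c(NC(=O)c3ccc(F)cc3)cc(-c3cccs3)nc21` gives 50000 nM. For the measured compounds named here, the one measured step, an at least 8.0-fold lower number from compound 1 to compound 2 (0.90 log units; beyond the scatter), concerns a different position and a different group, so no measured step bears on the change to compound 4 `CC(C)n1ncc2c(C(=O)Nc3ccc(F)cn3)cc(-c3cccs3)nc21`, (5-fluoropyridin-2-yl in place of 3-fluorophenyl on an amide-type nitrogen). Going by the values given here, with no comparable step in hand, the expectation for this assay is no shift beyond the scatter, a number no higher from compound 1 to compound 4 (the limit leaves the size open), and compound 4 is estimated at 200000 nM, between 100000 nM and 400000 nM, most likely again reported only as a limit.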

Compound 4, half-maximal cytotoxic concentration: > 200000 nM
Compound 4 ended at the assay's limit (the forecaster's own chance of this, stated with the estimate: 60%); the middle value sits exactly at the limit.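

For the compounds shown here, compound 1 and compound 4 both stand at a limit of the assay, not a number, so no step between them can be read: the limit of > 200000 nM in this assay, at which 2 of the 4 values shown sit. Going by these compounds, whether 5-fluoropyridin-2-yl in place of 3-fluorophenyl shifts the half-maximal cytotoxic concentration at all stays open.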